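Bromo to Methyl: Expected Cytotoxicity of Compound 4

The source may report more compounds than this note shows. Statements on the series, on what has been measured and on what is new or still open speak of the compounds shown alone.

Measured compounds:
compound 1 `Cc1ccc(-c2nn(-c3ccccc3)cc2CNc2ccccc2)cc1`: 52000 nM
compound 2 `Cc1ccc(-c2nn(-c3ccccc3)cc2CNc2ccc(Br)cc2)cc1`: 92000 nM
compound 3 `FC(F)(F)c1ccc(-c2nn(-c3ccccc3)cc2CNc2ccc(Br)cc2)cc1`: 17000 nM

In an ADME assay on Vero 76 cells (Chlorocebus sabaeus) for cytotoxicity, read by MTT assay, with a stated time of 96 h (on this read-out lower numbers stand for higher toxicity in this test and higher numbers for lower toxicity in this test), compound 3 gives the lowest number of the three, beyond the scatter from both others. For the measured compounds named here, the steps so far are a 1.8-fold higher number from compound 1 to compound 2 (0.25 log units; within the scatter) and a 5.4-fold lower number from compound 2 to compound 3 (0.73 log units; beyond the scatter). Compound 4 `Cc1ccc(NCc2cn(-c3ccccc3)nc2-c2ccc(C(F)(F)F)cc2)cc1` differs from compound 3 by methyl in place of bromo on an aromatic carbon. Only the first step bears on this change, since it moved the same position, and it stayed within the scatter. The second step touched a different group and does not inform this exchange. Compound 4 is therefore expected to stay close to compound 3, with a step of a 1.1-fold lower number from compound 3 to compound 4 (0.05 log units; within the scatter). The estimate for compound 4 in this assay is 15000 nM, with a range from 6000 nM to 40000 nM.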

Compound 4, half-maximal cytotoxic concentration: 82000 nM
Beside the measured number, compound 4's estimate is 5.5-fold (0.74 log units) below it, outside the stated range (above it).
By their numbers in this assay, from the lowest: compound 3; then compounds 1, 4 and 2 (each within the scatter of the next).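

In this assay the place on the ring that carries bromo proves responsive to this exchange, with a 4.8-fold higher number from compound 3 to compound 4 (0.68 log units; beyond the scatter) where trifluoromethyl stands on the other ring. The earlier change at this place, a 1.8-fold higher number from compound 1 to compound 2 (0.25 log units; within the scatter) where methyl stands on the other ring, had shown no movement beyond the scatter. Nothing in the available data accounts for the new step.

On these data alone, whether bromo to methyl moves the number as far when methyl replaces trifluoromethyl on the other ring remains open. So does the effect of chloro, methoxy or a carboxylic acid at this same place.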